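Ether side chains: from compound 3 to compound 4

The source may hold more compounds than are shown below. What is called first, only, known or untested is meant among the compounds shown, and "the series" means these compounds.

In a functional assay on MT2 cells (Homo sapiens) for cytotoxicity, read by MTT assay (a higher number here means that more compound is tolerated, a lower number that less compound is tolerated), compound 1 (`CC(C)=CCOc1cc(Nc2nccs2)ccc1C#N`) gives 750 nM while compound 2 (`N#Cc1ccc(Nc2nccs2)cc1OCc1ccco1`) gives 18000 nM and compound 3 (`N#Cc1ccc(Nc2nccs2)cc1OCc1nccs1`) gives 20000 nM in the same read-out. Compound 3 thus stands level with compound 2 and well above compound 1. Compound 4 (`N#Cc1ccc(Nc2nccs2)cc1OCC1=CCCC1`) differs from compound 3 as follows: cyclopent-1-en-1-yl in place of 1,3-thiazol-2-yl on a saturated chain carbon bound to an oxygen on an aromatic ring. Two large steps bear on this, a 24-fold higher number from compound 1 to compound 2 (1.38 log units; beyond the scatter) and a 27-fold higher number from compound 1 to compound 3 (1.43 log units; beyond the scatter) in turn, whereas a 1.1-fold higher number from compound 2 to compound 3 (0.05 log units; within the scatter) stays within the scatter. Like the 2-methylprop-1-en-1-yl of compound 1 at 750 nM the entering group has a double bond outside aromatic rings, so much of that rise should be undone in this assay by a large downward move. The expected step is an 8.0-fold lower number from compound 3 to compound 4 (0.90 log units; beyond the scatter) toward a lower number. For compound 4 the estimated value is 2500 nM with an expected range of 700 nM to 9000 nM in this read-out.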

Compound 4, half-maximal cytotoxic concentration: 1700 nM
Compound 4: the middle estimate sits 1.5-fold (0.17 log units) above what was measured; the range from low to high includes it.
By their numbers in this assay, from the lowest: compound 1; then compound 4; then compounds 2 and 3 (each within the scatter of the next).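

In this assay, cyclopent-1-en-1-yl gives a 12-fold lower number from compound 3 to compound 4 (1.07 log units; beyond the scatter) and an 11-fold lower number from compound 2 to compound 4 (1.02 log units; beyond the scatter), so the low numbers are not confined to the open 2-methylprop-1-en-1-yl group: in these four compounds, both groups with a double bond outside aromatic rings sit well below furan-2-yl and 1,3-thiazol-2-yl. The ring still does not fully match the open group, with a 2.3-fold higher number from compound 1 to compound 4 (0.36 log units; beyond the scatter). No evidence at hand bears on the reason for these steps.

Still open, as far as these compounds go, is where saturated cyclopentyl or n-pentyl would fall on the same saturated chain carbon. That would test whether the double bond or the carbon-only character of the group tracks the lower numbers.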